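Working notes: 5-methylpyridin-2-yl in place of 5-methylpyrazin-2-yl

The source may report more compounds than this note shows. Statements on the series, on what has been measured and on what is new or still open speak of the compounds shown alone.

- Compound 1 `Cc1cnc(NC(=O)c2cc(Oc3cnc(C(=O)N(C)C)cn3)c3cc(C)oc3c2)cn1`: < 8.5 mL/min/kg
- Compound 2 `Cc1cnc(NC(=O)c2cc(Oc3cnc(C(=O)N4CCCC4)cn3)c3cc(C)oc3c2)cn1`: < 8.1 mL/min/kg

In an ADME assay (liver) for metabolic stability, with Liver microsome (Homo sapiens) as the target, using microsomes (on this read-out lower numbers stand for slow clearance and higher numbers for fast clearance), compound 1 gives < 8.5 mL/min/kg, which is a limit and not a number. Compound 2 gives < 8.1 mL/min/kg, also a limit. Compound 3 `Cc1ccc(NC(=O)c2cc(Oc3cnc(C(=O)N(C)C)cn3)c3cc(C)oc3c2)nc1` differs from compound 1 in one place, on an amide-type nitrogen: 5-methylpyridin-2-yl in place of 5-methylpyrazin-2-yl on an amide-type nitrogen. Within the data shown here, no measured step covers this change. Among the measured compounds shown here, the only measured step is a step that the two limits leave unreadable from compound 1 to compound 2, which offers no size to carry over and concerns a different group, on a carbonyl carbon. The expectation is therefore weakly founded and is a tentative one. A modest estimated step of an at least 1.1-fold higher number from compound 1 to compound 3 (0.07 log units; that floor lies within the scatter) is expected, toward faster clearance. For compound 3 the expected value is 10 mL/min/kg. The estimated range for compound 3 runs from 5 mL/min/kg to 22 mL/min/kg.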

Compound 3, clearance: < 10.6 mL/min/kg
Compound 3 was reported as a limit (the forecaster's own chance of this, stated with the estimate: 40%); the middle value lies beyond the limit too.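

In this assay, compound 1 and compound 3 are both reported only as limits, so no step can be read between them. The compounds shown leave open whether 5-methylpyridin-2-yl in place of 5-methylpyrazin-2-yl on an amide-type nitrogen shifts clearance at all, and in which direction.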